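The source may hold more compounds than are shown below. What is called first, only, known or untested is meant among the compounds shown, and "the series" means these compounds.

In a functional assay on HepG2 cells (Homo sapiens) for inhibition, read by CCK-8 assay, with a stated time of 48 h (a lower number here means a stronger inhibitor, a higher number a weaker inhibitor), three compounds built on a shared core have been measured. Compound 1 (`Cc1ccc(C2=NN(C3=NC(c4ccccc4)CS3)C(c3ccc4ccccc4c3)C2)cc1`) gives 14700 nM and compound 2 (`Cc1ccc(C2=NN(C3=NC(=O)CS3)C(c3ccc4ccccc4c3)C2)cc1`) gives 12700 nM in that read-out, while compound 3 (`Cc1ccc(C2=NN(C3=NC(c4ccccc4)CS3)C(c3ccc4ccccc4c3)C2)cc1C`) gives 7370 nM and so stands within the scatter of both others. Compound 3 therefore has no clear separation from either of them.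

Compound 4 (`Cc1ccc(C2=NN(C3=NC(=O)CS3)C(c3ccc4ccccc4c3)C2)cc1C`) departs from compound 3 by a single exchange on an amine nitrogen in a ring: a group of 6 heavy atoms (3 carbon, 1 nitrogen, 1 oxygen, 1 sulfur; one five-membered non-aromatic ring with 2 hetero atoms) in place of a group of 11 heavy atoms (9 carbon, 1 nitrogen, 1 sulfur; one five-membered non-aromatic ring with 2 hetero atoms, one six-membered aromatic ring of carbon only), on an amine nitrogen in a ring. The same exchange has one measured precedent in a 1.2-fold lower number from compound 1 to compound 2 (0.06 log units; within the scatter) and that step lies within the scatter. The only other structural difference involved, methyl in place of hydrogen on an aromatic carbon, appears in a 2.0-fold lower number from compound 1 to compound 3 (0.30 log units; within the scatter) and that step also lies within the scatter. With a single precedent and no step beyond the scatter, the expected step in this assay is a 1.2-fold lower number from compound 3 to compound 4 (0.06 log units; within the scatter) and thus none beyond the scatter. For compound 4 the estimated value is 6400 nM with an expected range from 3000 nM to 13500 nM in this assay once it is measured.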

Compound 4, half-maximal inhibitory concentration: 8490 nM
Compound 4: the middle estimate sits 1.3-fold (0.12 log units) below what was measured, within the range that was stated.
By their numbers in this assay, from the lowest: compounds 3, 4, 2 and 1 (each within the scatter of the next).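

In this assay, putting the group of 6 heavy atoms in place of the group of 11 heavy atoms on the amine nitrogen in a ring gives a 1.2-fold higher number from compound 3 to compound 4 (0.06 log units; within the scatter), so this exchange now stays within the scatter with a 3,4-dimethylphenyl group on the core as well, and the two readings of it agree: the same change on two cores in this assay, a 1.2-fold lower number (0.06 log units; within the scatter) from compound 1 to compound 2 and a 1.2-fold higher number (0.06 log units; within the scatter) from compound 3 to compound 4, 1.3-fold (0.12 log units) apart, within the scatter of two such steps The added methyl, now read with the group of 6 heavy atoms in place, gives a 1.5-fold lower number from compound 2 to compound 4 (0.17 log units; within the scatter), and its two readings also agree: the same change on two cores in this assay, a 2.0-fold lower number (0.30 log units; within the scatter) from compound 1 to compound 3 and a 1.5-fold lower number (0.17 log units; within the scatter) from compound 2 to compound 4, 1.3-fold (0.12 log units) apart, within the scatter of two such steps Across these four compounds, neither change moves the number beyond the scatter, and the size of each step shows no clear dependence on the other change.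

The compounds shown leave open whether a different group on that amine nitrogen, such as one carrying an amine or a carboxylic acid, would move the number beyond the scatter in this assay. They also leave open what exchanging the naphthalen-2-yl group would do, as that group stands unchanged in all four compounds.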